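This account rests on a few compounds, and the source may have more. Where it says the series, first, only, none or still open, it means among the compounds named here.

Measured in a functional assay on HCT-116 cells (Homo sapiens) for antiproliferative activity, read by MTT assay, with a stated time of 72 h; on this read-out higher numbers stand for weaker inhibition and lower numbers for stronger inhibition:
Compound 1 `COc1ccc(N2CCN(C(=S)SCc3ccc4nc(N)nc(N)c4c3)CC2)cc1`: 2270 nM
Compound 2 `Nc1nc(N)c2cc(CSC(=S)N3CCN(c4ccccc4Cl)CC3)ccc2n1`: 5490 nM

Of these two compounds, compound 2 stands highest, at 5490 nM, and so is the weaker inhibitor in this assay. Compound 3 `CC(=O)c1ccc(N2CCN(C(=S)SCc3ccc4nc(N)nc(N)c4c3)CC2)cc1` differs from it as follows: 4-acetylphenyl in place of 2-chlorophenyl on an amine nitrogen in a ring. Among the measured compounds shown here, only one measured step bears on this change, since it concerns the same place: a 2.4-fold higher number from compound 1 to compound 2 (0.38 log units; beyond the scatter). That step is modest and replaces 4-methoxyphenyl with 2-chlorophenyl. For the measured compounds named here, compound 3 also gives up the 2-chlorophenyl, but no measured compound carries 4-acetylphenyl, so the direction rests on this single step. A small move toward lower numbers in this assay is therefore expected, no larger than the measured step and perhaps not clear of the scatter. The expected change is a 1.8-fold lower number from compound 2 to compound 3 (0.26 log units; within the scatter). For compound 3 the estimated value is 3000 nM, with an expected range of 1200 nM to 7500 nM.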

Compound 3, half-maximal inhibitory concentration: 8260 nM
Estimate against measurement, compound 3: 2.8-fold (0.44 log units) below; the measured number lies above the stated range.
By their numbers in this assay, from the lowest: compound 1; then compounds 2 and 3 (each within the scatter of the next).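

In this assay, the new aryl group does not separate compound 3 from the 2-chlorophenyl analogue: the comparison gives (a 1.5-fold higher number from compound 2 to compound 3 (0.18 log units; within the scatter)), which leaves the two indistinguishable at this position on the ring amine nitrogen. The 4-substituted ring alone therefore does not preserve the lower number, since acetyl in place of methoxy gives (a 3.6-fold higher number from compound 1 to compound 3 (0.56 log units; beyond the scatter)), a modest change beyond the scatter. Among these three compounds, only the 4-methoxyphenyl group of compound 1 stands apart, and nothing available here explains that difference.

Going by these compounds, it remains open whether a hydroxyl group or an amine at the same ring position would stay close to compound 1. The effect of an unsubstituted phenyl ring or a simple alkyl chain on this nitrogen is also unresolved.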